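The source may report more compounds than this note shows. Statements on the series, on what has been measured and on what is new or still open speak of the compounds shown alone.

Compound 1 `COc1ccc(-c2cc(/C=C/C(=O)c3ccc(N)cc3)[nH]n2)cc1`: -67%
Compound 2 `COc1cc(-c2cc(/C=C/C(=O)c3ccc(Cl)c(Cl)c3)[nH]n2)cc(OC)c1OC`: -25%
Compound 3 `COc1cc(-c2cc(/C=C/C(=O)c3ccc(F)c(F)c3)[nH]n2)cc(OC)c1OC`: -36%

In a functional assay on RPMI-8226 cells (Homo sapiens) for cytotoxicity, read by sulforhodamine B assay, with a stated time of 48 h, tested at 100 uM (a higher number here means a weaker effect of the compound at the concentration tested, a lower number a stronger effect), compound 1 gives the lowest number of the three, with compound 3 nearest and compound 2 furthest, both beyond the scatter. Compound 4 `COc1ccc(-c2cc(/C=C/C(=O)c3ccc(N)cc3)[nH]n2)cc1OC` differs from compound 1 by methoxy in place of hydrogen on an aromatic carbon, on an aromatic carbon of a six-membered aromatic ring of carbon only, ortho to a methoxy group. Going by the values given here, the only measured step, a number 11 percentage points lower from compound 2 to compound 3 (beyond the scatter), changes the ring on the carbonyl carbon, not the ring that changes here, so no measured step bears directly on this change. Compound 4 is therefore expected to stay near compound 1, with a number 7 percentage points higher from compound 1 to compound 4 (within the scatter) expected within the scatter. The estimate for compound 4 in this assay is -60%, between -82% and -32%.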

Compound 4, a percentage reported as activity, at one concentration (the size of the read-out at that concentration, not a potency): -40%
Estimate against measurement, compound 4: 20 percentage points below; the range from low to high includes it.
By their numbers in this assay, from the lowest: compound 1; then compounds 4 and 3 (each within the scatter of the next); then compound 2.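

In this assay, methoxy in place of hydrogen on an aromatic carbon, ortho to a methoxy group, gives a number 27 percentage points higher from compound 1 to compound 4 (beyond the scatter) and so weakens the effect at the concentration tested. Going by these compounds alone, this is the first measured step on this ring, and it shows that the position is not indifferent to substitution. No measurement at hand gives a reason for the shift.

The compounds shown leave open whether hydroxy, fluorine or a longer chain such as ethoxy would shift the number in the same direction at this position.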